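Hydrogen for fluoro in compound 2

The source may report more compounds than this note shows. Statements on the series, on what has been measured and on what is new or still open speak of the compounds shown alone.

Compound 1 `O=C(CN1CCN(c2nnc(Cc3ccncc3)c3ccccc23)CC1)Nc1cccc(Br)c1`: 1350 nM
Compound 2 `Cc1ccc(F)cc1NC(=O)CN1CCN(c2nnc(Cc3ccncc3)c3ccccc23)CC1`: 470 nM

In a functional assay on HT-29 cells (Homo sapiens) for cytotoxicity, read by MTT assay, with a stated time of 72 h (on this read-out higher numbers stand for weaker inhibition and lower numbers for stronger inhibition), compound 2 holds the lower of the two numbers. Within the data shown here, the single measured step, a 2.9-fold lower number from compound 1 to compound 2 (0.46 log units; beyond the scatter), leads to it. Compound 3 `Cc1ccccc1NC(=O)CN1CCN(c2nnc(Cc3ccncc3)c3ccccc23)CC1` differs from compound 2 in one place: hydrogen in place of fluoro on an aromatic carbon. The change is hydrogen in place of fluoro on an aromatic carbon, para to a methyl group. Among the measured compounds shown here, the measured step bears on this only loosely, since it replaced 3-bromophenyl with 5-fluoro-2-methylphenyl as a whole, and no measured pair isolates the fluoro. For the measured compounds named here, a smaller move than that step is therefore expected in this assay, possibly within the scatter, and more likely upward with compound 2 at 470 nM as the lowest number so far. The expected change is a 1.3-fold higher number from compound 2 to compound 3 (0.12 log units; within the scatter). For compound 3 the estimated value is 620 nM, with an expected range of 240 nM to 1600 nM.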

Compound 3, half-maximal inhibitory concentration: 15000 nM
Compound 3: middle estimate off by 24-fold (1.38 log units), on the low side; the whole stated range lies below it.
By their numbers in this assay, from the lowest: compound 2; then compound 1; then compound 3.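

In this assay, the single fluoro on the 5-fluoro-2-methylphenyl group proves far more important than the earlier comparison could reveal: hydrogen at this aromatic carbon, para to a methyl group, gives a 32-fold higher number from compound 2 to compound 3 (1.50 log units; beyond the scatter). With 2-methylphenyl in place of 3-bromophenyl, the result is an 11-fold higher number from compound 1 to compound 3 (1.05 log units; beyond the scatter), opposite in direction to a 2.9-fold lower number from compound 1 to compound 2 (0.46 log units; beyond the scatter), so among these compounds the methyl group without the fluoro does not bring the lower number. Nothing shown gives a cause for a change of this size.

From the compounds shown here alone, whether this result belongs to fluoro itself or would hold for another group at that carbon, such as chloro, methoxy or a nitrile, stays open. The compounds shown also leave open whether the fluoro would keep its effect without the methyl group.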